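From methoxy to hydroxy on compound 2

The compounds below may be only part of what the source reports. "The series", "measured", "known", "first", "only" and "open" are said of these compounds alone.

Compound 1 `COc1ccc(C(=O)/C=C/c2ccccc2-c2ccc(F)cc2)cc1`: 8800 nM
Compound 2 `COc1ccc(C(=O)/C=C/c2ccccc2-c2ccc(F)cc2)cc1OC`: 7100 nM
Compound 3 `COc1ccc(C(=O)/C=C/c2ccccc2-c2ccc(F)nc2)cc1OC`: 41000 nM

All three values come from a functional assay on MCF7 cells (Homo sapiens) for antiproliferative activity, read by sulforhodamine B assay, with a stated time of 48 h; on this read-out lower numbers stand for stronger inhibition and higher numbers for weaker inhibition. Compound 2 carries the lowest number of the three, but it lies within the scatter of compound 1 and clearly apart from compound 3 only. Compound 4 `COc1cc(C(=O)/C=C/c2ccccc2-c2ccc(F)cc2)ccc1O` has not yet been measured. It differs from compound 2 by hydrogen in place of methyl on an oxygen on an aromatic ring, which is hydrogen in place of methyl on an oxygen on an aromatic ring, or methoxy to hydroxy. Among the compounds with values here, no measured step makes this exact change. The closest in kind, methoxy in place of hydrogen on an aromatic carbon, gave a 1.2-fold lower number from compound 1 to compound 2 (0.09 log units; within the scatter). The exchange of 4-fluorophenyl for 6-fluoropyridin-3-yl gave a 5.8-fold higher number from compound 2 to compound 3 (0.76 log units; beyond the scatter), but it concerns a different group and says little here. Only a small step is therefore expected in this assay, quite possibly none beyond the scatter, with a slight lean towards a higher number. The expected step is a 1.2-fold higher number from compound 2 to compound 4 (0.08 log units; within the scatter). Compound 4 is estimated at 8500 nM, with an expected range from 3000 nM to 25000 nM.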

Compound 4, half-maximal inhibitory concentration: 5400 nM
Compound 4: middle estimate off by 1.6-fold (0.20 log units), on the high side, within the range that was stated.
By their numbers in this assay, from the lowest: compounds 4, 2 and 1 (each within the scatter of the next); then compound 3.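

In this assay, hydrogen in place of methyl on an oxygen on an aromatic ring gave a 1.3-fold lower number from compound 2 to compound 4 (0.12 log units; within the scatter), so this oxygen can carry either methoxy or hydroxy with no step beyond the scatter. Added to the earlier step of methoxy in place of hydrogen, a 1.2-fold lower number from compound 1 to compound 2 (0.09 log units; within the scatter), this is a second single change to the same aromatic ring that stays within the scatter, whereas only the exchange of 4-fluorophenyl has so far moved the number clearly. Nothing at hand gives a reason for this result.

The compounds shown leave open whether an amine or a longer alkoxy chain in place of the hydroxy would give a step beyond the scatter. They also leave open whether the hydroxy would hold with 6-fluoropyridin-3-yl, the exchange that gave a 5.8-fold higher number from compound 2 to compound 3 (0.76 log units; beyond the scatter) with the methoxy in place.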